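Trifluoromethyl on the pendant phenyl of the benzoxazinone imidazoles

The source may hold more compounds than are shown below. What is called first, only, known or untested is meant among the compounds shown, and "the series" means these compounds.

Measured compounds:
compound 1 `COc1ccc(-c2nc(-c3ccccc3)c(-c3ccc4c(c3)NC(=O)CO4)[nH]2)cc1`, 38.1%
compound 2 `O=C1COc2ccc(-c3[nH]c(-c4c[nH]c5ncccc45)nc3-c3ccccc3)cc2N1`, 86.8%
compound 3 `O=C1COc2ccc(-c3[nH]c(-c4ccccc4)nc3-c3ccccc3)cc2N1`, 58.5%

In a functional assay on A549 cells (Homo sapiens) for cytotoxicity, read by colorimetric assay and MTT assay, with a stated time of 3 days, tested at 20 uM (a lower number here means a stronger effect, a higher number a weaker effect of the compound at the concentration tested), compound 3 gives 58.5%, the second highest of the three numbers; its nearest neighbour is compound 1 at 38.1%, its furthest compound 2 at 86.8%. Compound 4 `O=C1COc2ccc(-c3[nH]c(-c4ccc(C(F)(F)F)cc4)nc3-c3ccccc3)cc2N1` has not yet been measured. It differs from compound 3 by trifluoromethyl in place of hydrogen on an aromatic carbon.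

The measured step that bears on this is a number 20.4 percentage points higher from compound 1 to compound 3 (beyond the scatter), a modest rise when a group on that same ring is replaced by hydrogen; going the other way, a group entering on that ring lowered the number. The step of a number 28.3 percentage points lower from compound 2 to compound 3 (beyond the scatter) concerns a different ring and is less informative. Within the data shown here, a trifluoromethyl has no precedent, so the direction is uncertain; a modest step downward, or none beyond the scatter, is expected.

For compound 4 a value of 48% is estimated, within 28% to 72%, which would mean an expected step of a number 10.5 percentage points lower from compound 3 to compound 4 (beyond the scatter).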

Compound 4, a percentage reported as activity, at one concentration (the size of the read-out at that concentration, not a potency): 21.7%
The estimate for compound 4 lay 26.3 percentage points above the measured number, outside the stated range (below it).
By their numbers in this assay, from the lowest: compound 4; then compound 1; then compound 3; then compound 2.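

On the pendant phenyl in this assay, trifluoromethyl in place of hydrogen gives a number 36.8 percentage points lower from compound 3 to compound 4 (beyond the scatter) and shows that this position tolerates a substituent with a large fall in the number, where methoxy had brought only a modest one. The two substituents are not interchangeable here, since trifluoromethyl in place of methoxy gives a number 16.4 percentage points lower from compound 1 to compound 4 (beyond the scatter) at the same place. The widest span in the series is now a number 65.1 percentage points lower from compound 2 to compound 4 (beyond the scatter) with the 4-(trifluoromethyl)phenyl group in place of the other aromatic group, which leaves the new compound lowest of the four and beyond the scatter against each of the others.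

Open, on these data alone, is whether a nitrile, a chlorine or a dimethylamino group at this place would fall with trifluoromethyl or nearer to methoxy. Nothing at hand accounts for the size of this fall.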